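The source may hold more compounds than are shown below. What is called first, only, known or untested is meant among the compounds shown, and "the series" means these compounds.

Going by the values given here, compound 1 `COc1ccc(F)c(-c2ccc3c(NC(=O)c4ccc(N(C)CCN(C)C)cc4)n[nH]c3c2)c1F` is the only member of the set with a definite number in a functional assay on KG-1 cells (Homo sapiens) for antiproliferative activity, read by CCK-8 assay, with a stated time of 72 h; a higher number here means a weaker inhibitor, a lower number a stronger inhibitor: compound 1 gives 333 nM. Compound 2 `CCN1CCN(c2ccc(C(=O)Nc3n[nH]c4cc(-c5cccc(OC)c5F)ccc34)cc2C(F)(F)F)CC1` reaches only a limit in this assay, giving > 1000 nM. Compound 3 `CCN1CCN(c2ccc(C(=O)Nc3n[nH]c4cc(-c5cccc(OC)c5F)cc(F)c34)cc2)CC1` likewise stops at a limit, giving > 1000 nM. Two of the three values therefore sit at the limit of > 1000 nM in this assay, at which 2 of the 3 values shown sit, and compound 1 stands alone as the one measurable point from which any step can be taken.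

Compound 4 `COc1ccc(F)c(-c2ccc3c(NC(=O)c4ccc(N5CCCN(C)CC5)cc4)n[nH]c3c2)c1F` has not yet been measured. It differs from compound 1 in a single place (4-methyl-1,4-diazepan-1-yl in place of (2-(dimethylamino)ethyl)(methyl)amino on an aromatic carbon), that is, 4-methyl-1,4-diazepan-1-yl in place of (2-(dimethylamino)ethyl)(methyl)amino on an aromatic carbon, para to a large group. Among the compounds with values here, no step between measured compounds touches this part of the molecule, so there is nothing among the numbers to set a direction. The change is expected to move this assay by no more than the usual scatter, with a 1.2-fold higher number from compound 1 to compound 4 (0.08 log units; within the scatter) as the expected step. Compound 4 is accordingly estimated at 400 nM, between 150 nM and 1100 nM.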

Compound 4, half-maximal inhibitory concentration: 51.5 nM
Beside the measured number, compound 4's estimate is 7.8-fold (0.89 log units) above it; measured number outside the range, below it.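

Placing 4-methyl-1,4-diazepan-1-yl where (2-(dimethylamino)ethyl)(methyl)amino stood gives, in this assay, a 6.5-fold lower number from compound 1 to compound 4 (0.81 log units; beyond the scatter). Going by these compounds alone, this is the first readable step in the set, and it shows that this position, on an aromatic carbon para to a large group, is sensitive to the group it carries, even though both groups count the same hydrogen-bond donors and acceptors and no net charge. The open chain and the seven-membered non-aromatic ring are a single pair, however, so it cannot say what in the change produces the step.

Going by these compounds, whether 4-methylpiperazin-1-yl or a morpholine at this place on the core of compound 1 would follow compound 4 remains open. Compound 2 and compound 3 differ from compound 4 in more than one place and each gives only a limit, so no step to them can be read: the limit of > 1000 nM in this assay, at which 2 of the 4 values shown sit.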